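Returning to a Single Hydroxyl on the Amide Chain

A few compounds are considered here, and "the series" means these few. Any claim that something is new, unique, unknown or untested is made for them only; others in the source may bear on it.

Compound 2 `COc1cccc2cc(C(=O)NC(CO)(CO)CO)c(=N)oc12` carries a 2-hydroxy-1,1-bis(hydroxymethyl)ethyl group on the amide-type nitrogen of the shared core. For the measured compounds named here, in an assay on HEK293 cells for displacement of a labelled ligand from adenosine receptor A2b (Homo sapiens), read by scintillation counting, with a stated time of 30 min, tested at 10 uM (on this read-out higher numbers stand for more inhibition at the one concentration tested (going by the name of the read-out) and lower numbers for less inhibition), compound 2 gives 28%, the lowest of the two numbers measured so far. Going by the values given here, its only measured neighbour, compound 1 `COc1cccc2cc(C(=O)NCCO)c(=N)oc12`, has the smaller 2-hydroxyethyl group in the same place, and in this assay compound 1 gives 65%. Among the compounds with values here, the single known step, a number 37 percentage points lower from compound 1 to compound 2 (beyond the scatter), is large.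

Compound 3 `COc1cccc2cc(C(=O)NCCCCCO)c(=N)oc12` swaps the branched group for a straight chain: 5-hydroxypentyl in place of 2-hydroxy-1,1-bis(hydroxymethyl)ethyl on an amide-type nitrogen. Within the data shown here, the entering group brings one hydrogen-bond donor and one hydrogen-bond acceptor, as the 2-hydroxyethyl group of compound 1 does, so this change largely undoes the one measured step. Among the measured compounds shown here, since adding the two extra hydroxymethyl arms cost a large amount of inhibition, taking them away is expected to regain much of it, although the longer 5-hydroxypentyl chain itself has no measured counterpart here. Compound 3 is therefore expected to give 55% in this assay, with a likely range from 35% to 75%, an estimated step of a number 27 percentage points higher from compound 2 to compound 3 (beyond the scatter).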

Compound 3, a percentage reported as inhibition, at one concentration (the size of the read-out at that concentration, not a potency): > 70%
Compound 3 ended at the assay's limit; the forecaster's own chance of this, stated with the estimate: 0%; at least 15 percentage points between middle value and limit.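

In this assay compound 3 gives > 70%, and this is a limit of the assay, not an exact number: the limit of > 70% in this assay, at which 1 of the 3 values shown sits. Replacing the branched group with a straight chain on the amide-type nitrogen gives a number at least 42 percentage points higher from compound 2 to compound 3 (beyond the scatter), so this position can carry a chain well beyond 2-hydroxyethyl and still give a high number, while the low reading belongs only to the branched group with three hydroxymethyl arms. Extending the chain gives a number at least 5 percentage points higher from compound 1 to compound 3 (that floor lies within the scatter), a floor that does not separate the two straight chains, so the data show no cost from the longer 5-hydroxypentyl chain but cannot show a gain.

The limit hides how much inhibition compound 3 really reaches, so the compounds shown cannot say whether the number with the 5-hydroxypentyl chain is truly higher than with the 2-hydroxyethyl chain or how inhibition changes with length. They also leave open whether the terminal hydroxyl matters at all, which a plain pentyl chain, an amine or a carboxylic acid at the chain end would test, and whether the loss in compound 2 follows from the branching itself or from its extra hydroxyl groups.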